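The source may report more compounds than this note shows. Statements on the series, on what has been measured and on what is new or still open speak of the compounds shown alone.

Measured compounds:
compound 1, `CC(=O)Oc1ccccc1C(=O)O[C@H]1CO[C@H]2[C@@H]1OC[C@H]2OC(=O)c1snnc1C`, 0.0642 h
compound 2, `CC(=O)Oc1ccccc1C(=O)O[C@H]1CO[C@H]2[C@@H]1OC[C@H]2OC(=O)c1cccc(O)c1`, 0.0183 h

Going by the values given here, in an ADME assay on a cell-free system (plasma, Homo sapiens) for metabolic stability, with Plasma (Rattus norvegicus) as the target, read by HPLC, at pH 7.4 (a lower number here means that the compound disappears faster, a higher number that the compound lasts longer), compound 2 gives 0.0183 h, the lowest of the two numbers so far; its nearest neighbour is compound 1, and the only measured step, a 3.5-fold lower number from compound 1 to compound 2 (0.55 log units; beyond the scatter), runs from that neighbour down to compound 2. Compound 3, `CC(=O)Oc1ccccc1C(=O)O[C@H]1CO[C@H]2[C@@H]1OC[C@H]2OC(=O)c1ccc(O)cc1`, is not yet measured in this assay. Its difference from compound 2 is 4-hydroxyphenyl in place of 3-hydroxyphenyl on a carbonyl carbon. Among the compounds with values here, the one measured step concerns a different exchange, a thiadiazolyl group for a hydroxyphenyl group, and says nothing about moving the hydroxyl within the phenyl ring; no step in this set bears on that change. With nothing to point either way, the number for compound 3 is expected to stay close to that of compound 2, with a step of a 1.1-fold higher number from compound 2 to compound 3 (0.04 log units; within the scatter) that lies within the scatter. The estimate for compound 3 in this assay is 0.02 h, expected to fall between 0.008 h and 0.05 h.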

Compound 3, half-life: 0.0198 h
For compound 3 the middle estimate is 1.0-fold (0.00 log units) above the measured one; low and high end bracket the measured number.
By their numbers in this assay, from the lowest: compounds 2 and 3 (each within the scatter of the next); then compound 1.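

In this assay, the shift of the hydroxyl, 4-hydroxyphenyl in place of 3-hydroxyphenyl on the carbonyl carbon, gives a 1.1-fold higher number from compound 2 to compound 3 (0.03 log units; within the scatter), so this position does not separate the two hydroxyphenyl groups. The exchange of 4-methyl-1,2,3-thiadiazol-5-yl now stands in a second form, a 3.2-fold lower number from compound 1 to compound 3 (0.51 log units; beyond the scatter), so the gap first seen with 3-hydroxyphenyl does not depend on that one placement of the hydroxyl. No outside evidence bears on these numbers.

As far as these compounds go, whether a plain phenyl, an aminophenyl or a carboxylic acid on the phenyl ring at this position would fall with the hydroxyphenyl compounds or with compound 1 remains open. The compounds also leave open how the half-life responds to any change elsewhere on the shared core.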